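Replacing a Trifluoromethylphenyl Carbonyl with a Dichlorophenyl Carbamoyl

The source may hold more compounds than are shown below. What is called first, only, known or untested is meant among the compounds shown, and "the series" means these compounds.

Of the compounds shown here, two on a shared core have so far been tested in a functional assay on SNB-75 cells (Homo sapiens) for inhibition, read by sulforhodamine B assay, with a stated time of 48 h; on this read-out lower numbers stand for higher toxicity in this test and higher numbers for lower toxicity in this test. Compound 1 `COc1cc(-c2nn(-c3cccc(NC(=O)Nc4cc(C(F)(F)F)cc(C(F)(F)F)c4)c3)cc2-c2ccncc2)ccc1Cl` gives 5310 nM. Compound 2 `COc1cc(-c2nn(-c3cccc(NC(=O)c4cccc(C(F)(F)F)c4)c3)cc2-c2ccncc2)ccc1Cl` reaches only a limit of the assay, reported as > 50000 nM. Compound 2 thus stands at the limit of > 50000 nM in this assay, at which 1 of the 2 values shown sits, and no number of its own is known for it. Compound 3 `COc1cc(-c2nn(-c3cccc(NC(=O)Nc4ccc(Cl)c(Cl)c4)c3)cc2-c2ccncc2)ccc1Cl` has not yet been measured; it differs from compound 2 in a single place: (3,4-dichlorophenyl)amino in place of 3-(trifluoromethyl)phenyl on a carbonyl carbon. Among the measured compounds shown here, no measured pair shows this change directly, so its size can only be anticipated. Compound 2 reaches only a limit of the assay. Because compound 1 gives a finite value of 5310 nM, the step from compound 2 to compound 3 is expected to be an at least 6.2-fold lower number from compound 2 to compound 3 (0.79 log units; beyond the scatter), toward higher toxicity. The value expected for compound 3 in this assay is 8000 nM, with a likely range from 2500 nM to 40000 nM.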

Compound 3, concentration lethal to 50% of the cells: > 50000 nM
Compound 3: a limit, no number; the forecaster's own chance of this, stated with the estimate: 20%; middle value at least 6.2-fold (0.79 log units) away from the limit.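

In this assay compound 3 gives > 50000 nM, which is a limit of the assay. Compound 2 also sits at a limit, so no step can be read between compound 2 and compound 3: the limit of > 50000 nM in this assay, at which 2 of the 3 values shown sit.

The compounds shown leave open the size and direction of the change from 3-(trifluoromethyl)phenyl to (3,4-dichlorophenyl)amino in this assay.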